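The source may hold more compounds than are shown below. What is called first, only, known or untested is meant among the compounds shown, and "the series" means these compounds.

Compound 1 `Clc1cccc(Cn2cc(COc3ccccc3)nn2)c1` in a physicochemical assay, read by spectrophotometry, with a stated time of 30 min (a lower number here means a stronger inhibitor, a higher number a weaker inhibitor), gives 27.3 ug/mL.
Compound 2 `Brc1ccc(Cn2cc(COc3ccccc3)nn2)cc1` in this assay gives 18.3 ug/mL.
Compound 3 `O=[N+]([O-])c1cccc(OCc2cn(Cc3cccc(Cl)c3)nn2)c1` in this assay gives 31.2 ug/mL.

Compound 2 is obtained from compound 1 by 4-bromophenyl in place of 3-chlorophenyl on a saturated chain carbon bound to an aromatic nitrogen. Compound 3 differs from compound 1 by nitro in place of hydrogen on an aromatic carbon, a step of a 1.1-fold higher number from compound 1 to compound 3 (0.06 log units; within the scatter). Compound 4 `O=[N+]([O-])c1cccc(OCc2cn(Cc3ccc(Br)cc3)nn2)c1` has not yet been measured in this assay. It differs from compound 3 by 4-bromophenyl in place of 3-chlorophenyl on a saturated chain carbon bound to an aromatic nitrogen, the same change that turns compound 1 into compound 2, now made on the core that carries the nitro group. Because that earlier change gave a 1.5-fold lower number from compound 1 to compound 2 (0.17 log units; within the scatter), a step of about the same size is expected here, namely a 1.5-fold lower number from compound 3 to compound 4 (0.17 log units; within the scatter). This expectation rests on a single earlier example, so it is held loosely. Compound 4 is therefore estimated at 21 ug/mL, expected to fall between 13 ug/mL and 34 ug/mL.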

Compound 4, half-maximal inhibitory concentration: 29.4 ug/mL
Beside the measured number, compound 4's estimate is 1.4-fold (0.15 log units) below it; low and high end bracket the measured number.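

In this assay the change from 3-chlorophenyl to 4-bromophenyl on the core carrying the nitro group gives a 1.1-fold lower number from compound 3 to compound 4 (0.03 log units; within the scatter) while adding the nitro group to the bromine-bearing compound gives a 1.6-fold higher number from compound 2 to compound 4 (0.21 log units; within the scatter) and neither step leaves the scatter. On the core without the nitro group the same change gave a 1.5-fold lower number from compound 1 to compound 2 (0.17 log units; within the scatter) so on both cores it stays within the scatter, which fits with it carrying over but cannot show a real effect on either core or a real difference between them. Nothing else available speaks to the reason for these numbers.

The compounds shown leave open whether an amine or a carboxylic acid in place of the nitro group would give a larger step. They also leave open what a longer chain in place of the 4-bromobenzyl would do.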